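Changing the aryl group on the carbonyl of a tracheal relaxant

A few compounds are considered here, and "the series" means these few. Any claim that something is new, unique, unknown or untested is made for them only; others in the source may bear on it.

Of the compounds shown here, three sharing one core have been tested in a functional assay (trachea) with Rattus norvegicus as the target; a higher number here means a more potent compound, by a factor of ten per unit of this negative logarithm, a lower number a less potent compound. Compound 1 `CC1(C)C=C(n2ccccc2=O)c2cc(C(=O)c3ccccc3)ccc2O1` gives 6.21. Compound 2 `CC1(C)C=C(n2ccccc2=O)c2cc(C(=O)c3cccs3)ccc2O1`, with thiophen-2-yl in place of phenyl on the carbonyl carbon, gives 5.84, and that change is a number 0.37 log units lower from compound 1 to compound 2 (beyond the scatter). Compound 3 `CC1(C)C=C(n2ccccc2=O)c2cc(C(=O)c3ccc([N+](=O)[O-])cc3)ccc2O1` gives 6.09. Compound 3 sits close to both of the others: the step of a number 0.12 log units lower from compound 1 to compound 3 (within the scatter) and the step of a number 0.25 log units higher from compound 2 to compound 3 (within the scatter) are each within the scatter, so compound 3 cannot be told apart from compound 1 or compound 2 on these numbers.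

Compound 4 `CC1(C)C=C(n2ccccc2=O)c2cc(C(=O)c3ccccc3C(F)(F)F)ccc2O1` differs from compound 3 only at the carbonyl carbon: 2-(trifluoromethyl)phenyl in place of 4-nitrophenyl on a carbonyl carbon. Among the measured compounds shown here, no measured step involves 2-(trifluoromethyl)phenyl, so the only guide is that exchanging one aryl group for another here has so far produced at most a modest step, as in a number 0.37 log units lower from compound 1 to compound 2 (beyond the scatter), and otherwise none beyond the scatter. A small step in either direction, or none, is therefore expected. Compound 4 is estimated at 6, with a range from 5.5 to 6.5. That estimate means an expected step of a number 0.09 log units lower from compound 3 to compound 4 (within the scatter).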

Compound 4, logarithm of the reciprocal of the active concentration, log(1/C): 5.78
The estimate for compound 4 lay 0.22 log units above the measured number; the measured number falls inside the stated range.
By their numbers in this assay, from the lowest: compounds 4, 2, 3 and 1 (each within the scatter of the next, the first and the last beyond it).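

In this assay, adding trifluoromethyl to the phenyl group of compound 1 gives a number 0.43 log units lower from compound 1 to compound 4 (beyond the scatter), the first substituent on that ring with a step beyond the scatter, since nitro gave only a number 0.12 log units lower from compound 1 to compound 3 (within the scatter) in a different form of the ring. The two substituted phenyl groups can also now be told apart, with a number 0.31 log units lower from compound 3 to compound 4 (beyond the scatter), so the choice of substituted aryl group at this carbonyl carbon can matter, while a number 0.06 log units lower from compound 2 to compound 4 (within the scatter) leaves 2-(trifluoromethyl)phenyl and thiophen-2-yl indistinguishable. No measurement here explains these steps.

Because compound 3 and compound 4 differ in both the substituent and its place on the ring, these compounds cannot separate those two factors, and 4-(trifluoromethyl)phenyl would help to do so. From the compounds shown here alone, how an amine on the carbonyl carbon in place of an aryl group would behave also remains open.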